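The compounds below may be only part of what the source reports. "The series", "measured", "known", "first", "only" and "open" are said of these compounds alone.

Compound 1 `COc1ccc(-c2coc3cc(OCCCBr)ccc3c2=O)cc1` gives 62600 nM
Compound 2 `COc1ccc(-c2coc3cc(OCCCSC(=S)N4CCOCC4)ccc3c2=O)cc1` gives 27400 nM

Going by the values given here, in a functional assay on PC-3 cells (Homo sapiens) for inhibition, read by MTT assay, with a stated time of 48 h (a lower number here means a stronger inhibitor, a higher number a weaker inhibitor), compound 2 gives 27400 nM as the lower of the two numbers so far. Compound 3 `COc1ccc(-c2coc3cc(OCCBr)ccc3c2=O)cc1` differs from compound 2 by one bromine atom in place of a group of 10 heavy atoms (6 carbon, 1 nitrogen, 1 oxygen, 2 sulfur; one six-membered non-aromatic ring with 2 hetero atoms), on a saturated chain carbon, two bonds along the chain from an oxygen on an aromatic ring and so carries bromo as compound 1 does. Among the compounds with values here, the one measured step bearing on this is a 2.3-fold lower number from compound 1 to compound 2 (0.36 log units; beyond the scatter) and it is modest. A step of similar size in the opposite direction, toward a higher number, is therefore expected in this assay. Within the data shown here, no measurement yet separates two bonds along the chain from three. The expected change is a 2.0-fold higher number from compound 2 to compound 3 (0.30 log units; within the scatter) as estimated here. Compound 3 is estimated at 55000 nM with 25000 nM to 120000 nM as the expected range.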

Compound 3, half-maximal inhibitory concentration: 41900 nM
Beside the measured number, compound 3's estimate is 1.3-fold (0.12 log units) above it; the measured number falls inside the stated range.
By their numbers in this assay, from the lowest: compounds 2, 3 and 1 (each within the scatter of the next, the first and the last beyond it).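

In this assay, on a saturated chain carbon, two bonds along the chain from an oxygen on an aromatic ring, bromo and the larger ring-bearing group cannot be told apart (a 1.5-fold higher number from compound 2 to compound 3 (0.18 log units; within the scatter)). Bromo in place of bromomethyl is likewise unresolved (a 1.5-fold lower number from compound 1 to compound 3 (0.17 log units; within the scatter)), so compound 3 sits within the scatter of both compound 1 and compound 2, although those two stand apart. No measurement available here explains these numbers.

Open, as far as these compounds go, is whether an amine or a longer chain in place of bromo would move the number beyond the scatter.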